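A few compounds are considered here, and "the series" means these few. Any claim that something is new, unique, unknown or untested is made for them only; others in the source may bear on it.

Three compounds share one core and differ only at an oxygen on a saturated carbon. Compound 1 `OC1C[C@@H]2CCCC[C@@H]2[C@H]1/C=C/c1ccc(-c2cccc(F)c2)cn1` carries a hydrogen there and gives 220 nM in an assay on cell membranes for displacement of a labelled ligand from proteinase-activated receptor 1 (Homo sapiens), read by scintillation counting, with a stated time of 60 min; on this read-out higher numbers stand for weaker inhibition and lower numbers for stronger inhibition. Compound 2 `Fc1cccc(-c2ccc(/C=C/[C@H]3C(OCc4ccccc4)C[C@@H]4CCCC[C@@H]43)nc2)c1` carries a benzyl and gives 280 nM in this assay; a 1.3-fold higher number from compound 1 to compound 2 (0.10 log units; within the scatter). Compound 3 `CC(=O)OC1C[C@@H]2CCCC[C@@H]2[C@H]1/C=C/c1ccc(-c2cccc(F)c2)cn1` carries an acetyl and gives 67 nM in this assay, the lowest number of the three: a 3.3-fold lower number from compound 1 to compound 3 (0.52 log units; beyond the scatter), and a 4.2-fold lower number from compound 2 to compound 3 (0.62 log units; beyond the scatter). Compound 4 `O=C(Nc1ccccc1)OC1C[C@@H]2CCCC[C@@H]2[C@H]1/C=C/c1ccc(-c2cccc(F)c2)cn1` has not yet been measured. It differs from compound 3 by anilino in place of methyl on a carbonyl carbon. Going by the values given here, none of the measured steps touches this carbonyl carbon; the nearest guidance is that a benzyl in place of hydrogen on the oxygen left the number within the scatter, whereas an acetyl in place of hydrogen or benzyl lowered it modestly. A ring-bearing group on the oxygen thus did not raise the number beyond the scatter, and the carbonyl of compound 3 is retained in compound 4. The step from compound 3 to compound 4 is therefore expected to be small, a 1.0-fold higher number from compound 3 to compound 4 (0.02 log units; within the scatter). Compound 4 is estimated at 70 nM in this assay, with a range from 25 nM to 200 nM.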

Compound 4, half-maximal inhibitory concentration: 360 nM
For compound 4 the middle estimate is 5.1-fold (0.71 log units) below the measured one; measured number outside the range, above it.
By their numbers in this assay, from the lowest: compound 3; then compounds 1, 2 and 4 (each within the scatter of the next).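

In this assay the carbonyl on the oxygen does not by itself go with the lower number: anilino in place of methyl on the carbonyl carbon gives the step (a 5.4-fold higher number from compound 3 to compound 4 (0.73 log units; beyond the scatter)), which removes the advantage held by compound 3. The phenylcarbamoyl group stays level with hydrogen (a 1.6-fold higher number from compound 1 to compound 4 (0.21 log units; within the scatter)) and with benzyl (a 1.3-fold higher number from compound 2 to compound 4 (0.11 log units; within the scatter)), so among the four groups on this oxygen only the acetyl stands apart. Nothing shown bears on why that is so.

The anilino brings its ring and its nitrogen together, so a phenyl or a methylamino on the carbonyl carbon would be needed to tell which of the two goes with the higher number. Going by these compounds, how far the methyl can be extended also stays open, for instance to an ethyl or a longer chain on that carbon.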